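The compounds below may be only part of what the source reports. "The series", "measured", "known", "first", "only" and "open" are said of these compounds alone.

Compound 1 `CN(Cc1ccccc1)C(=O)c1cc2c(Cc3ccccc3Cl)n[nH]c2cc1O`, compound 2 `Cc1ccccc1Cc1n[nH]c2cc(O)c(C(=O)N(C)Cc3ccccc3)cc12`, compound 3 `CN(Cc1ccccc1)C(=O)c1cc2c(Cc3cccc(F)c3)n[nH]c2cc1O` and compound 4 `CN(Cc1ccccc1)C(=O)c1cc2c(Cc3cccc(Cl)c3)n[nH]c2cc1O` share one core and differ only in the substituent on the benzyl group. In a functional assay on A2780 cells (Homo sapiens) for antiproliferative activity, read by resazurin assay, with a stated time of 72 h (on this read-out lower numbers stand for stronger inhibition and higher numbers for weaker inhibition), compound 3 gives 1700 nM. Within the data shown here, that is the only number available so far. Compound 1 is entered as "not determined" (no result reported), and compound 2 is entered as "not determined" (no result reported). Neither offers a comparison, so compound 3 cannot yet be called strong or weak within this small set.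

Compound 4 differs from compound 3 at a single place: chloro in place of fluoro on an aromatic carbon. In words, this is chloro in place of fluoro on an aromatic carbon, which turns the 3-fluorobenzyl into a 3-chlorobenzyl. Among the measured compounds shown here, no measured pair here shows what this kind of swap does, so the expectation can lean only on the single value of compound 3 at 1700 nM. With only one substituent exchanged, no step beyond the usual scatter of repeated measurements is expected, and no direction is firmly favoured. In this assay the expected step, a 1.2-fold lower number from compound 3 to compound 4 (0.08 log units; within the scatter), is therefore an estimate that stays within that scatter. Compound 4 is estimated at 1400 nM, with an expected range from 550 nM to 3800 nM.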

Compound 4, half-maximal inhibitory concentration: 410 nM
Estimate against measurement, compound 4: 3.4-fold (0.53 log units) above, and the stated range ends above it.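

Swapping fluoro for chloro on the benzyl group gives a 4.1-fold lower number from compound 3 to compound 4 (0.62 log units; beyond the scatter) in this assay, so this place on the ring is sensitive to the exchange of a single atom, something one isolated value could not show. The change is also a spare one: the two groups match in heavy-atom count, neither adds a hydrogen-bond donor or acceptor, and neither carries a net charge, so these counts do not separate the 3-fluorobenzyl from the 3-chlorobenzyl although the read-out does. Nothing measured here explains the difference between the two groups.

As far as these compounds go, compound 1 and compound 2 have no reported numbers, so the steps that would link them to compound 3 or compound 4 cannot be read, and the effect of moving or replacing the substituent remains unknown. From the compounds shown here alone, one pair also gives no sense of a wider pattern, so it remains open what a bromo, a methoxy or an amine at this same place would do, or how a plain benzyl group with only hydrogen there would compare.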